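The source may report more compounds than this note shows. Statements on the series, on what has been measured and on what is new or still open speak of the compounds shown alone.

Measured compounds:
Compound 1, `CC(C)OC(=O)N1CCC(Oc2ncnc3c2CCN3c2ccc(F)cn2)CC1`, gives in a functional assay on CHO-K1 cells for agonist activity at Glucose-dependent insulinotropic receptor (Homo sapiens), read by a luciferase reporter, with a stated time of 5 h (a lower number here means that less compound is needed, a higher number that more compound is needed for the effect), the limit > 10000 nM, a boundary of the measurement rather than a number.
Compound 2, `CC(C)OC(=O)N1CCC(Oc2ncnc3c2CCN3c2ccc([S+]([O-])N(C)C)cc2)CC1`, gives in this assay 501 nM.

Among the compounds with values here, compound 2 therefore holds the only real number in this assay; the other value is the limit of > 10000 nM in this assay, at which 1 of the 2 values shown sits. Within the data shown here, the one measured step, an at least 19-fold lower number from compound 1 to compound 2 (1.30 log units; beyond the scatter), came from swapping the group on the nitrogen on the aromatic ring in a ring, and it was large.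

Compound 3, `Cc1cc(S(C)(=O)=O)ccc1N1CCc2c(OC3CCN(C(=O)OC(C)C)CC3)ncnc21`, is not yet measured. It differs from compound 2 by a group of 11 heavy atoms (8 carbon, 2 oxygen, 1 sulfur; one six-membered aromatic ring of carbon only) in place of a group of 11 heavy atoms (8 carbon, 1 nitrogen, 1 oxygen, 1 sulfur; one six-membered aromatic ring of carbon only), on a nitrogen on an aromatic ring in a ring. Among the measured compounds shown here, no measured pair shows a change of this kind, where one sulfur-bearing aryl group replaces another at the same place; the step from compound 1 to compound 2 concerned a different swap and does not settle it. The expectation is a step within the scatter, a 1.7-fold lower number from compound 2 to compound 3 (0.22 log units; within the scatter), in this assay. Compound 3 is therefore estimated at 300 nM, with a likely range from 80 nM to 1500 nM.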

Compound 3, half-maximal effective concentration: 100 nM
Estimate against measurement, compound 3: 3.0-fold (0.48 log units) above; low and high end bracket the measured number.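

The group on the nitrogen of the five-membered non-aromatic ring still moves the result when sulfur-bearing aryl groups are exchanged for one another: in this assay, 2-methyl-4-(methylsulfonyl)phenyl gives a 5.0-fold lower number from compound 2 to compound 3 (0.70 log units; beyond the scatter). So the gain at this place does not end with the first sulfur-bearing group, and compared with 5-fluoropyridin-2-yl the new group gives an at least 100-fold lower number from compound 1 to compound 3 (2.00 log units; beyond the scatter). The size of that larger step has only a lower bound, and compound 1 stands at a limit of the assay, not at a number: the limit of > 10000 nM in this assay, at which 1 of the 3 values shown sits.

The methyl group and the methylsulfonyl group enter together, so the compounds shown do not separate what each contributes. Also open, on these data alone, is how the result would respond to a chlorine in place of that methyl, or to a carboxylic acid in place of the methylsulfonyl group.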